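Rat liver clearance: replacing pyrrolidin-1-yl in compound 2

This account rests on a few compounds, and the source may have more. Where it says the series, first, only, none or still open, it means among the compounds named here.

Measured in an ADME assay on S9 fraction from liver (Rattus norvegicus, strain Wistar) for metabolic stability, tested at 0.1 uM; a higher number here means faster removal of the compound, a lower number slower removal:
- compound 1 `CCOC(=O)CN(C)c1cc(OCc2cc(F)c(Oc3ccc(Cl)c(C(F)(F)F)c3)c(F)c2)nc(=O)n1C`: 13.8 mL/min/kg
- compound 2 `Cn1c(N2CCCC2)cc(OCc2cc(F)c(Oc3ccc(Cl)c(C(F)(F)F)c3)c(F)c2)nc1=O`: 3.11 mL/min/kg
- compound 3 `CN1CCN(c2cc(OCc3cc(F)c(Oc4ccc(Cl)c(C(F)(F)F)c4)c(F)c3)nc(=O)n2C)CC1`: 1140 mL/min/kg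

Of the three, compound 2 has the lowest number in this assay, and both of its steps to the others lie beyond the scatter. The next candidate is compound 4 `Cn1c(N2CCC(F)(F)CC2)cc(OCc2cc(F)c(Oc3ccc(Cl)c(C(F)(F)F)c3)c(F)c2)nc1=O`, with this change from compound 2: 4,4-difluoropiperidin-1-yl in place of pyrrolidin-1-yl on an aromatic carbon.

Going by the values given here, no measured compound carries this amine, so the steps offer only indirect guidance. The replacement of 4-methylpiperazin-1-yl for pyrrolidin-1-yl gave a 370-fold higher number from compound 2 to compound 3 (2.56 log units; beyond the scatter), a large step. That step rests on a single compound, and 4-methylpiperazin-1-yl is not 4,4-difluoropiperidin-1-yl, so it is not expected to carry over in full. The other step, a 4.4-fold lower number from compound 1 to compound 2 (0.65 log units; beyond the scatter), is modest and shows that compound 2 also lies under compound 1. A modest rise is therefore expected, an estimated 2.6-fold higher number from compound 2 to compound 4 (0.41 log units; beyond the scatter). For compound 4 the estimated clearance is 8 mL/min/kg, with an expected range from 2.5 mL/min/kg to 30 mL/min/kg.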

Compound 4, clearance: 23.6 mL/min/kg
Compound 4: middle estimate off by 3.0-fold (0.47 log units), on the low side; measured number inside the range.
By their numbers in this assay, from the lowest: compound 2; then compounds 1 and 4 (each within the scatter of the next); then compound 3.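

In this assay, the step of a 7.6-fold higher number from compound 2 to compound 4 (0.88 log units; beyond the scatter) shows that the low number of compound 2 does not extend to every saturated ring amine at this place on the shared core. The high number of compound 3 does not extend to them either, as a 48-fold lower number from compound 3 to compound 4 (1.68 log units; beyond the scatter) is a large drop with 4,4-difluoropiperidin-1-yl in place of 4-methylpiperazin-1-yl. The step of a 1.7-fold higher number from compound 1 to compound 4 (0.23 log units; within the scatter) lies within the scatter, so the open-chain ((ethoxycarbonyl)methyl)(methyl)amino group and 4,4-difluoropiperidin-1-yl cannot be ordered here, and no measurement on hand explains any of these differences.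

Whether the larger ring or the two fluorine atoms account for the rise from compound 2 remains open. Piperidin-1-yl without fluorine, or 3,3-difluoropyrrolidin-1-yl, would separate the two, and morpholin-4-yl would test a ring oxygen in place of the methylated ring nitrogen of compound 3.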